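The compounds below may be only part of what the source reports. "The series", "measured", "known", "first", "only" and "open" are said of these compounds alone.

Compound 1 `COc1ccc2[nH]c(=O)c(-c3nc4ccccc4[nH]3)cc2c1` in a functional assay on BEL-7404 cells for cytotoxicity against BEL-7404 tumor cell line (Homo sapiens), read by MTT assay, with a stated time of 48 h (on this read-out higher numbers stand for weaker inhibition and lower numbers for stronger inhibition), gives > 100000 nM, a limit of the assay and not a number.
Compound 2 `Cc1ccc2[nH]c(=O)c(-c3nc4cc([N+](=O)[O-])ccc4[nH]3)cc2c1` in this assay gives > 100000 nM, likewise a limit and not a number.
Compound 3 `O=c1[nH]c2ccccc2cc1-c1nc2cc([N+](=O)[O-])ccc2[nH]1` in this assay gives > 100000 nM, again a limit and not a number.

Compound 3 therefore stands at the edge of what this assay can report, and so do the other two measured compounds: the limit of > 100000 nM in this assay, at which 3 of the 3 values shown sit. Going by the values given here, the one measured step that joins two of them, a step that the two limits leave unreadable from compound 2 to compound 3, is the change of hydrogen in place of methyl on an aromatic carbon. Both of its ends are limits. Its size cannot be read.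

Compound 4 `O=c1[nH]c2ccccc2cc1-c1nc2cc(Cl)ccc2[nH]1` differs from compound 3 by chloro in place of nitro on an aromatic carbon. Among the compounds with values here, no measured step involves a chloro group, and the only measured step that involves a nitro group is the unreadable one from compound 2 to compound 3, so nothing in the numbers says how large a step to expect in this assay or in which direction. With every measured value sitting at the limit, the expectation for compound 4 is that it too most probably remains at or near that limit. The step from compound 3 to compound 4 is estimated as a step that the limit leaves unreadable from compound 3 to compound 4, and compound 4 is estimated at 150000 nM, within a range from 30000 nM to 600000 nM.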

Compound 4, half-maximal inhibitory concentration: 16500 nM
Beside the measured number, compound 4's estimate is 9.1-fold (0.96 log units) above it; the whole stated range lies above it.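

In this assay this position proves responsive to the group it carries: chloro in place of nitro on the six-membered aromatic ring of carbon only gives an at least 6.0-fold lower number from compound 3 to compound 4 (0.78 log units; beyond the scatter), a step beyond the scatter and the only readable step among the compounds shown. The value of compound 3, > 100000 nM, is a limit of the assay and not a number, so the size printed for this step is a bound and not an exact distance. Compound 4 is the only compound here with a measured number, and it alone has left the edge of what the assay reports: the limit of > 100000 nM in this assay, at which 3 of the 4 values shown sit.

Whether this gain belongs to chloro itself or would follow other replacements of nitro stays open, as the compounds shown carry no fluoro, bromo or amine at this position. On these data alone, the step between the two nitro compounds cannot be read, so it also remains unknown whether a methyl or a methoxy group elsewhere on the shared core would add anything once chloro is in place.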